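Adding a Ring Hydroxy Group on Two Related Cores

The compounds below may be only part of what the source reports. "The series", "measured", "known", "first", "only" and "open" are said of these compounds alone.

Compound 1 `CSc1nc2cnsc2n1[C@H]1C[C@H](O)[C@@H](CO)O1` and compound 2 `CSc1nc2sncc2n1[C@H]1C[C@H](O)[C@@H](CO)O1` are built from the same atoms joined differently; the difference between the two cores is not broken down here. In a functional assay on HFF cells (Homo sapiens) for inhibition (a higher number here means a weaker inhibitor, a lower number a stronger inhibitor), compound 2 gives 15000 nM. For compound 1 the reading in this assay is a limit of the assay, > 100000 nM. Compound 3 `CSc1nc2cnsc2n1[C@@H]1O[C@H](CO)[C@@H](O)[C@@H]1O` carries one added group on the core of compound 1: hydroxy in place of hydrogen on a saturated ring carbon. For compound 3 the reading in this assay is again a limit, > 100000 nM. The step that the two limits leave unreadable from compound 1 to compound 3 cannot be sized because of the limit of > 100000 nM in this assay, at which 2 of the 3 values shown sit. Compound 4 `CSc1nc2sncc2n1[C@@H]1O[C@H](CO)[C@@H](O)[C@@H]1O` carries the same change on the core of compound 2: hydroxy in place of hydrogen on a saturated ring carbon. With the earlier step unreadable, the expected step of a 2.7-fold higher number from compound 2 to compound 4 (0.43 log units; beyond the scatter) rests only on compound 2 at 15000 nM and is given wide uncertainty. Compound 4 is therefore estimated at 40000 nM, between 10000 nM and 150000 nM.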

Compound 4, half-maximal inhibitory concentration: 21000 nM
Beside the measured number, compound 4's estimate is 1.9-fold (0.28 log units) above it; low and high end bracket the measured number.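

On the core of compound 2, putting hydroxy in place of hydrogen on a saturated ring carbon gives a 1.4-fold higher number from compound 2 to compound 4 (0.15 log units; within the scatter) in this assay and so the two compounds cannot be told apart there. The same change on the core of compound 1 cannot be read, because both compounds on that core sit at a limit: the limit of > 100000 nM in this assay, at which 2 of the 4 values shown sit. This leaves one readable step on one core, so it does not show whether the change carries from one core to the other.

The compounds shown leave open whether an amine or a methoxy group on that same ring carbon would read differently from hydroxy on the core of compound 2. They also leave open how any such group would read on the core of compound 1.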